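Methoxy in Place of Hydrogen on the Shared Core

The compounds below may be only part of what the source reports. "The series", "measured", "known", "first", "only" and "open" are said of these compounds alone.

Compound 1, `CCCc1cccc(=O)n1Cc1ccc(-c2ccccc2-c2nn[nH]n2)cc1`: 1.1 mg/kg
Compound 2, `CCCCc1cc(O)cc(=O)n1Cc1ccc(-c2ccccc2-c2nn[nH]n2)cc1`: 0.38 mg/kg

Both were measured in a functional assay on the whole organism with Rattus norvegicus as the target; on this read-out lower numbers stand for an effect already at smaller amounts and higher numbers for an effect only at larger amounts of compound. Compound 1 has the highest of the two numbers; compound 2 gives a lower one, and the two structures differ in more than one place, so their values alone tell the story. Compound 3, `CCCc1cc(OC)cc(=O)n1Cc1ccc(-c2ccccc2-c2nn[nH]n2)cc1`, awaits measurement. It differs from compound 1 by methoxy in place of hydrogen on an aromatic carbon. A modest move toward a lower number is expected, as compound 2, which also carries a group at that position, gives 0.38 mg/kg. For compound 3 the expected step is a 1.8-fold lower number from compound 1 to compound 3 (0.26 log units; within the scatter), barely beyond the scatter. The estimate for compound 3 is 0.6 mg/kg, between 0.25 mg/kg and 1.5 mg/kg.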

Compound 3, dose for 50% inhibition: 0.24 mg/kg
Compound 3: the middle estimate sits 2.5-fold (0.40 log units) above what was measured; the measured number lies below the stated range.
By their numbers in this assay, from the lowest: compounds 3 and 2 (each within the scatter of the next); then compound 1.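

Swapping hydrogen for methoxy on this aromatic carbon, opposite the ring nitrogen, gives a 4.6-fold lower number from compound 1 to compound 3 (0.66 log units; beyond the scatter). Compound 2 differs from compound 1 in more than one place. Within the data shown here, this is the first comparison that isolates a single change, and it shows that a group at this position can go with a lower dose in the rat. Nothing measured here explains the shift.

As far as these compounds go, it remains open whether an ethoxy group, an amine or a fluorine atom at this position would lower the number further, or raise it instead.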